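The compounds below may be only part of what the source reports. "The series", "measured", "known", "first", "only" and "open" are said of these compounds alone.

Measured so far:
- compound 1, `COc1cc2c(cc1OC)C(CC(=O)Nc1ccccc1C)CC2`, in a functional assay on the whole organism (strain Wistar) for inhibition, with Rattus norvegicus as the target, read by paw edema, with a stated time of 3 h, at a dose of 100 mg/kg (on this read-out lower numbers stand for less inhibition and higher numbers for more inhibition at the one dose given (going by the name of the read-out)), gives 26.1%
- compound 2, `COc1ccccc1NC(=O)CC1CCc2cc(OC)c(OC)cc21`, gives 21.7%

Compound 2 and compound 1 lie within the scatter of each other: a number 4.4 percentage points lower from compound 1 to compound 2 (within the scatter). Compound 3, `COc1cc2c(cc1OC)C(CC(=O)Nc1ccncc1)CC2`, differs from compound 2 by pyridin-4-yl in place of 2-methoxyphenyl on an amide-type nitrogen. For the measured compounds named here, the one measured step, methoxy in place of methyl on an aromatic carbon, concerns a substituent of the aryl ring and not an exchange of the whole group on the amide-type nitrogen, so no measured step bears directly on this change. The step of a number 0.3 percentage points higher from compound 2 to compound 3 (within the scatter) is therefore expected to stay within the scatter. Compound 3 is estimated at 22%, in a range of 6% to 38%.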

Compound 3, a percentage reported as inhibition, in the whole organism at one dose (the size of the read-out at that dose, not a potency): 42%
Compound 3: middle estimate off by 20 percentage points, on the low side; the whole stated range lies below it.
By their numbers in this assay, from the lowest: compounds 2 and 1 (each within the scatter of the next); then compound 3.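

In this assay, replacing the whole group on the amide-type nitrogen moves the read-out, whereas the substituent swap on the aryl ring did not: pyridin-4-yl in place of 2-methoxyphenyl gives (a number 20.3 percentage points higher from compound 2 to compound 3 (beyond the scatter)), and pyridin-4-yl in place of 2-methylphenyl gives (a number 15.9 percentage points higher from compound 1 to compound 3 (beyond the scatter)). This position therefore responds to the identity of the aromatic group, and a ring with a hetero atom is the better of those compared. No evidence on hand accounts for the rise.

Still open, from the compounds shown here alone, is whether unsubstituted phenyl would read like compound 3, which would separate the ring nitrogen from the loss of the methoxy or methyl substituent. The effect of moving the ring nitrogen, as in pyridin-3-yl, is also unresolved.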